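This account rests on a few compounds, and the source may have more. Where it says the series, first, only, none or still open, it means among the compounds named here.

Measured in a functional assay on SGC-7901 cells (Homo sapiens) for antiproliferative activity, read by MTT assay, with a stated time of 72 h; on this read-out higher numbers stand for weaker inhibition and lower numbers for stronger inhibition:
- compound 1 `COc1ccc(-c2ccc3ncn(-c4cc(OC)c(OC)c(OC)c4)c3c2)cc1F`: 430 nM
- compound 2 `COc1cc(-n2cnc3ccc(-c4cccc([N+](=O)[O-])c4)cc32)cc(OC)c1OC`: 380 nM

Not yet measured: compound 3 `COc1cc(-n2cnc3ccc(-c4ccc(Cl)cc4)cc32)cc(OC)c1OC`.

In this assay, going by the values given here, compound 2 gives 380 nM, and the two measured compounds cannot be ordered: the only step is a 1.1-fold lower number from compound 1 to compound 2 (0.05 log units; within the scatter). The next change is 4-chlorophenyl in place of 3-nitrophenyl on an aromatic carbon. The measured step is a single exchange of one substituted phenyl for another, so it is thin evidence, but it gives no reason to expect a shift beyond the scatter in this assay, in either direction. The estimated step is a 1.2-fold higher number from compound 2 to compound 3 (0.07 log units; within the scatter). Compound 3 is expected at 450 nM, with an estimated range of 150 nM to 1400 nM.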

Compound 3, half-maximal inhibitory concentration: 1270 nM
Compound 3: middle estimate off by 2.8-fold (0.45 log units), on the low side; low and high end bracket the measured number.
By their numbers in this assay, from the lowest: compounds 2 and 1 (each within the scatter of the next); then compound 3.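

In this assay this position proves not indifferent to the aryl group it carries: 4-chlorophenyl in place of 3-nitrophenyl gives a 3.3-fold higher number from compound 2 to compound 3 (0.52 log units; beyond the scatter) and 4-chlorophenyl in place of 3-fluoro-4-methoxyphenyl gives a 3.0-fold higher number from compound 1 to compound 3 (0.47 log units; beyond the scatter) and both steps lie beyond the scatter. Going by these compounds alone, the first exchange at this position gave no such separation, so 4-chlorophenyl is the first group here to stand apart from the others. Nothing available bears on the reason for this shift.

A single chlorinated compound cannot separate the effect of the chlorine from that of its place on the ring. On these data alone, how an aminophenyl or a carboxyphenyl group would compare at this position remains open.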